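Tert-butyl in place of methyl on compound 1

A few compounds are considered here, and "the series" means these few. Any claim that something is new, unique, unknown or untested is made for them only; others in the source may bear on it.

Going by the values given here, in an ADME assay on microsomes from liver (Rattus norvegicus) for metabolic stability, read by LC-MS, using NADPH, with a stated time of 30 min, tested at 1 uM (on this read-out higher numbers stand for fast clearance and lower numbers for slow clearance), compound 1 `Cc1cc(-c2ccc([C@H](C)Nc3nccc(N4C(=O)OC[C@@H]4C(C)C)n3)nc2)ccn1` gives 68 mL.min-1.g-1 as the lower of the two numbers available so far. Compound 2 `Cc1nc([C@H](C)Nc2nccc(N3C(=O)OC[C@@H]3C(C)C)n2)ccc1-c1ccnc(C(F)(F)F)c1` gives 141 mL.min-1.g-1 and this gap lies beyond the usual scatter. Among the compounds with values here, no measured pair yet isolates a single structural change.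

Compound 3 `CC(C)[C@H]1COC(=O)N1c1ccnc(N[C@@H](C)c2ccc(-c3ccnc(C(C)(C)C)c3)cn2)n1` departs from compound 1 by tert-butyl in place of methyl on an aromatic carbon with tert-butyl in place of methyl on an aromatic carbon, next to the ring nitrogen. Within the data shown here, no measured step exists for this change, so any expectation in this assay is tentative. Among the measured compounds shown here, the only guide to the upper part of the measured range is compound 2 at 141 mL.min-1.g-1 in this series. The expected step of a 2.2-fold higher number from compound 1 to compound 3 (0.34 log units; beyond the scatter) is towards faster clearance and modestly beyond the scatter. For compound 3 the estimated value is 150 mL.min-1.g-1 with an expected range from 85 mL.min-1.g-1 to 265 mL.min-1.g-1 on this read-out.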

Compound 3, intrinsic clearance in microsomes: 235 mL.min-1.g-1
Compound 3: the middle estimate sits 1.6-fold (0.19 log units) below what was measured; the measured number falls inside the stated range.
By their numbers in this assay, from the lowest: compound 1; then compounds 2 and 3 (each within the scatter of the next).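

In this assay, going by these compounds alone, the change from 2-methylpyridin-4-yl to 2-(tert-butyl)pyridin-4-yl provides the first single-place step, a 3.5-fold higher number from compound 1 to compound 3 (0.54 log units; beyond the scatter), with the rest of compound 1 unchanged. At this aromatic carbon next to the ring nitrogen, tert-butyl in place of methyl therefore goes with faster clearance, so this position is not silent in this read-out. No available measurement bears on the origin of the step, which leaves only its direction and size on record.

One step cannot show whether clearance rises gradually from methyl to tert-butyl or only with tert-butyl itself, and ethyl or isopropyl at this carbon would separate the two. A methoxy group or an amine there would test whether the direction holds beyond alkyl groups.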